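Replacing dimethylamino with cyclopentylsulfanyl on the shared core

A few compounds are considered here, and "the series" means these few. Any claim that something is new, unique, unknown or untested is made for them only; others in the source may bear on it.

Compound 1 `Nc1nc(NC2CC2)c2ncn(/C=C3/CC3(CO)CO)c2n1`: > 300000 nM (a limit)
Compound 2 `CCCCCOc1nc(N)nc2c1ncn2/C=C1/CC1(CO)CO`: 259000 nM
Compound 3 `CN(C)c1nc(N)nc2c1ncn2/C=C1/CC1(CO)CO`: > 300000 nM (a limit)

In an ADME assay on HFF cells (Homo sapiens) for cytotoxicity, with a stated time of 8 days (a higher number here means that more compound is tolerated, a lower number that less compound is tolerated), compound 1 gives > 300000 nM, which is a limit of the assay and not a number. In this assay compound 2 gives 259000 nM. Compound 3 gives > 300000 nM in this assay, again a limit of the assay. So compound 3 stands at the upper edge of what was measured, sharing that edge with compound 1 (the limit of > 300000 nM in this assay, at which 2 of the 3 values shown sit). Between the compounds the steps are small: an at least 1.1-fold higher number from compound 2 to compound 3 (0.06 log units; that floor lies within the scatter), and a step that the two limits leave unreadable from compound 1 to compound 3. Compound 4 `Nc1nc(SC2CCCC2)c2ncn(/C=C3/CC3(CO)CO)c2n1` differs from compound 3 in one place: cyclopentylsulfanyl in place of dimethylamino on an aromatic carbon. Among the measured compounds shown here, the only measured step onto compound 3, an at least 1.1-fold higher number from compound 2 to compound 3 (0.06 log units; that floor lies within the scatter), lies within the scatter, and the three values shown do not spread out beyond it. The step of an at least 1.2-fold lower number from compound 3 to compound 4 (0.07 log units; that floor lies within the scatter) is therefore expected to stay within the scatter. Compound 4 is estimated to give 250000 nM in this assay, with a range from 100000 nM to 300000 nM.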

Compound 4, half-maximal cytotoxic concentration: > 300000 nM
Compound 4 ended at the assay's limit; the forecaster's own chance of this, stated with the estimate: 50%; at least 1.2-fold (0.07 log units) between middle value and limit.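

With cyclopentylsulfanyl, the position now holds a group with sulfur and a five-membered ring of carbon only, and in this assay compound 4 gives > 300000 nM, which is a limit of the assay. Cyclopentylsulfanyl in place of pentyloxy gives an at least 1.1-fold higher number from compound 2 to compound 4 (0.06 log units; that floor lies within the scatter), while the steps from compound 3 and from compound 1 cannot be read, with limits at both ends. New here is that a group with sulfur at this position also leaves the read-out at the upper edge: the limit of > 300000 nM in this assay, at which 3 of the 4 values shown sit.

As far as these compounds go, how far compounds 1, 3 and 4 would really lie past that limit stays unknown, so no order among them can be given. From the compounds shown here alone, whether a carboxylic acid or a longer chain on sulfur at this position would bring the number down also stays open.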